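The source may report more compounds than this note shows. Statements on the series, on what has been measured and on what is new or still open speak of the compounds shown alone.

Of the compounds shown here, two have been measured so far. Compound 1, with the structure `CCCCC(Sc1nc(N)c2cnn(-c3ccccc3)c2n1)C(N)=O`, carries an amino group on its core and gives the lower of the two numbers in an assay for displacement of a labelled ligand from adenosine receptor A1 (Rattus norvegicus) (a higher number here means a weaker inhibitor, a lower number a stronger inhibitor), a value of 0.939 nM. Compound 2, with the structure `CCCC(Sc1nc(S)c2cnn(-c3ccccc3)c2n1)C(N)=O`, carries a sulfanyl group in that position and a shorter chain on the side arm; in this assay compound 2 gives 56.3 nM, a gap from compound 1 that lies well beyond the usual scatter. Compound 3, with the structure `CCCCC(Sc1nc(S)c2cnn(-c3ccccc3)c2n1)C(N)=O`, keeps the chain of compound 1 and makes only the change (sulfanyl in place of amino on an aromatic carbon). Among the compounds with values here, no measured pair shows this change alone, so the expectation rests on what compound 2 shows. The step of a 32-fold higher number from compound 1 to compound 3 (1.50 log units; beyond the scatter) is expected to be a clear weakening, beyond the scatter. Compound 3 is therefore expected to give about 30 nM in this assay, somewhere between 6 nM and 150 nM.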

Compound 3, inhibition constant: 37.2 nM
The estimate for compound 3 lay 1.2-fold (0.09 log units) below the measured number, and the stated range covers the measured number.
By their numbers in this assay, from the lowest: compound 1; then compounds 3 and 2 (each within the scatter of the next).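

In this assay, the swap of amino for sulfanyl on this aromatic carbon can now be read alone, with the rest of the molecule unchanged: a 40-fold higher number from compound 1 to compound 3 (1.60 log units; beyond the scatter) is a large step, so this one atom weighs heavily. Methyl in place of hydrogen on the saturated chain carbon, by contrast, gives a 1.5-fold lower number from compound 2 to compound 3 (0.18 log units; within the scatter), so with sulfanyl on the core the two chain lengths cannot be told apart. Nothing available here bears on why the swap on the core has so large an effect.

From the compounds shown here alone, whether a methylamino group or a hydroxyl group on this aromatic carbon would stay close to compound 1 or to compound 3 remains open. The chain step is also known only with sulfanyl on the core, so a shorter or longer chain alongside the amino group is an open question.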